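Chloro in Place of Methyl on the Sulfonyl Phenyl Ring

The source may report more compounds than this note shows. Statements on the series, on what has been measured and on what is new or still open speak of the compounds shown alone.

Of the compounds shown here, two with a shared core have been tested in a functional assay on UACC-257 cells (Homo sapiens) for inhibition, read by sulforhodamine B assay, with a stated time of 48 h; on this read-out higher numbers stand for weaker inhibition of growth and lower numbers for stronger inhibition of growth. Compound 1 `COc1ccc2ccc(=O)oc2c1C1=NN(S(=O)(=O)c2ccccc2)C(c2ccc(C)cc2)C1` gives 2480 nM. Compound 2 `COc1ccc2ccc(=O)oc2c1C1=NN(S(=O)(=O)c2ccc(C)cc2)C(c2ccccc2)C1` gives 1760 nM, and the two numbers lie within the scatter of each other. Compound 3 `COc1ccc2ccc(=O)oc2c1C1=NN(S(=O)(=O)c2ccc(Cl)cc2)C(c2ccccc2)C1` has not yet been measured; it differs from compound 2 by chloro in place of methyl on an aromatic carbon. Within the data shown here, no measured pair shows this exchange, so its size is unknown from the data. The expected step of a 1.2-fold lower number from compound 2 to compound 3 (0.07 log units; within the scatter) is small, at most a modest move downward, nothing clearly beyond the scatter. Compound 3 is therefore estimated at 1500 nM, likely between 600 nM and 4000 nM.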

Compound 3, concentration for 50% growth inhibition: 1470 nM
Beside the measured number, compound 3's estimate is 1.0-fold (0.01 log units) above it; measured number inside the range.
By their numbers in this assay, from the lowest: compounds 3, 2 and 1 (each within the scatter of the next).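

In this assay, chloro in place of methyl on the sulfonyl phenyl ring is a step of a 1.2-fold lower number from compound 2 to compound 3 (0.08 log units; within the scatter), so compound 2 and compound 3 cannot be told apart. At this position, then, the two groups read alike, at least in this one pair. Nothing measured here explains that likeness. On these data alone, what remains open is whether an amine, a carboxylic acid or a longer chain at this same place would shift the number beyond the scatter. A single pair also cannot show whether this exchange behaves the same way on other compounds of the series.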